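The compounds below may be only part of what the source reports. "The series", "measured", "known", "first", "only" and "open" are said of these compounds alone.

Working notes on the series in a functional assay on HCT-116 cells (Homo sapiens) for cytotoxicity, read by sulforhodamine B assay; a lower number here means that less compound is needed, a higher number that more compound is needed for the effect. Compound 1 `CCCCCCCCCCCCCCCCCCCCCCCCc1cn([C@@H](CO)[C@H](O)[C@H](O)CCCCCCCCCCCCCC)nn1` reads > 50000 nM, which is a limit of the assay and not a number. Compound 3 `CCCCCCCCCCCCCC[C@@H](O)[C@@H](O)[C@H](CO)n1cc(CCCCCC)nn1` gives 12000 nM. Compound 2 `CCCCCCCCCCCCC/C=C/[C@@H](O)[C@H](CO)n1cc(CCC)nn1` gives 16000 nM, within the scatter of the value for compound 3, so the two numbers do not separate these compounds.

Compound 4 `CCCCCCCCCCCCC/C=C/[C@@H](O)[C@H](CO)n1cc(CCCCCCCCCCCCC)nn1` departs from compound 2 by decyl in place of hydrogen on a saturated chain carbon, three bonds along the chain from an aromatic carbon. Going by the values given here, no measured step covers this change, so the expectation rests on thin support. Among the compounds with values here, the one compound with a very long chain at this part of the structure is compound 1, at > 50000 nM, again a limit. A modest upward move is therefore expected, and the expected step of a 1.6-fold higher number from compound 2 to compound 4 (0.19 log units; within the scatter) may end close to that limit. For compound 4 the estimated value is 25000 nM, with an expected range of 10000 nM to 50000 nM.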

Compound 4, half-maximal effective concentration: > 50000 nM
Compound 4: a limit, no number (the forecaster's own chance of this, stated with the estimate: 35%); at least 2.0-fold (0.30 log units) between middle value and limit.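

Going by these compounds alone, this is the first measured step at this position: decyl in place of hydrogen on a saturated chain carbon, three bonds along the chain from an aromatic carbon, gives an at least 3.1-fold higher number from compound 2 to compound 4 (0.49 log units; beyond the scatter). In this assay compound 4 reads > 50000 nM, a limit of the assay and not a number, so the step has a floor but no measured size. On this core, the added decyl thus takes the reading out of the measurable range, and the comparison stops at that edge: the limit of > 50000 nM in this assay, at which 2 of the 4 values shown sit.

Where the reading leaves the measurable range as the chain grows stays open, and an octyl chain at this position would bear on that. Also open, from the compounds shown here alone, is whether an amine or a carboxylic acid at the end of a chain this long would bring the value back into range.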